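This account rests on a few compounds, and the source may have more. Where it says the series, first, only, none or still open, it means among the compounds named here.

Three amides of the same core were tested in a functional assay on SW-620 cells (Homo sapiens) for cytotoxicity, read by MTT assay, with a stated time of 48 h; a lower number here means a stronger inhibitor, a higher number a weaker inhibitor. Compound 1 `CCCCCCCCCCCCNC(=O)[C@@H](NC(=O)c1ccccc1)[C@@H](C)O` gives 200000 nM. Compound 2 `CCCCCCCCCCCCNC(=O)[C@@H](NC(=O)c1ccco1)[C@@H](C)O` carries furan-2-yl in place of phenyl on a carbonyl carbon and gives 87500 nM, a step of a 2.3-fold lower number from compound 1 to compound 2 (0.36 log units; beyond the scatter). Compound 3 `CCCCCCCCCCCCCCNC(=O)[C@@H](NC(=O)c1ccccc1)[C@@H](C)O` gives 200000 nM, and the step is no change at the digits printed from compound 1 to compound 3 (within the scatter), so compound 3 and compound 1 stand level, together the highest of the three numbers, with compound 2 furthest from compound 3.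

Compound 4 `CCCCCCCCCCCCCCNC(=O)[C@@H](NC(=O)c1ccco1)[C@@H](C)O` has not yet been measured in this assay. It differs from compound 3 by furan-2-yl in place of phenyl on a carbonyl carbon. Going by the values given here, this is the same change as the one between compound 1 and compound 2, made in the same place, and it occurs twice among the four compounds. The two cores on which it is made differ by ethyl in place of hydrogen on a saturated chain carbon, ten or more bonds along the chain from an amide-type nitrogen, a change that left the number unmoved from compound 1 to compound 3.

Because the same change gave a 2.3-fold lower number from compound 1 to compound 2 (0.36 log units; beyond the scatter) on the core of compound 1, and because the core change gave no change at the digits printed from compound 1 to compound 3 (within the scatter), a step of about a 2.2-fold lower number from compound 3 to compound 4 (0.35 log units; beyond the scatter) is expected for compound 4. Compound 4 is therefore estimated at 90000 nM, expected to lie between 45000 nM and 200000 nM.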

Compound 4, half-maximal inhibitory concentration: 200000 nM
For compound 4 the middle estimate is 2.2-fold (0.35 log units) below the measured one; the measured number falls inside the stated range.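

In this assay, the change to furan-2-yl from phenyl on the core of compound 3 gives no change at the digits printed from compound 3 to compound 4 (within the scatter), and set beside the same change on the core of compound 1 it does not separate from the earlier step: the same change on two cores in this assay, a 2.3-fold lower number (0.36 log units; beyond the scatter) from compound 1 to compound 2 and no change at the digits printed (within the scatter) from compound 3 to compound 4, 2.3-fold (0.36 log units) apart, within the scatter of two such steps The chain change, read on the furan-2-yl amides, gives a 2.3-fold higher number from compound 2 to compound 4 (0.36 log units; beyond the scatter), and it too stays together with its earlier step: the same change on two cores in this assay, no change at the digits printed (within the scatter) from compound 1 to compound 3 and a 2.3-fold higher number (0.36 log units; beyond the scatter) from compound 2 to compound 4, 2.3-fold (0.36 log units) apart, within the scatter of two such steps This shows that the four compounds give no firm sign that either change depends on the core, but it does not show that either change carries over with its size intact, since a single pair of steps can settle neither.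

The compounds shown leave open whether a thiophene or pyridine ring on the carbonyl carbon would follow furan-2-yl or phenyl in this assay. They also leave open how a shorter chain, a longer chain, or a chain ending in an amine or a carboxylic acid would read on either core.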